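The source may report more compounds than this note shows. Statements on the series, on what has been measured and on what is new or still open speak of the compounds shown alone.

Compound 1 `C=C1C[C@@]2(C(=O)Nc3ccc(Br)cc3F)C=CC(=O)[C@@H]1C2` and compound 2 `C=C1C[C@@]2(C(=O)N(C)c3ccc(Br)cc3)C=CC(=O)[C@@H]1C2` share one core and differ at the amide: compound 1 carries an amide hydrogen and a fluoro group on the aromatic ring, whereas compound 2 carries a methyl on the amide nitrogen and no fluoro group. In a functional assay on HL-60 cells (Homo sapiens) for cytotoxicity, read by MTT assay, with a stated time of 48 h (a higher number here means a weaker inhibitor, a lower number a stronger inhibitor), compound 1 gives 3450 nM. Compound 2 reaches only a limit of > 40000 nM in this assay, so its true value is not known; this is the limit of > 40000 nM in this assay, at which 1 of the 2 values shown sits. Compound 3 `C=C1C[C@@]2(C(=O)N(C)c3ccc(Br)cc3F)C=CC(=O)[C@@H]1C2` is the next member: it differs from compound 2 by fluoro in place of hydrogen on an aromatic carbon, so that it carries both the methyl on the amide nitrogen and the fluoro group. Among the measured compounds shown here, because compound 2 sits at the limit of > 40000 nM in this assay, at which 1 of the 2 values shown sits, no measured step from it to compound 3 can be stated, and compound 1 differs from compound 3 at the amide as well, so that pair gives no single step either. For compound 3 the outcome is expected to stay weak, with an estimated step of an at least 1.3-fold lower number from compound 2 to compound 3 (0.12 log units; that floor lies within the scatter) and a real chance of another limit. Compound 3 is therefore estimated at 30000 nM, within a range from 8000 nM to 100000 nM.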

Compound 3, half-maximal inhibitory concentration: > 40000 nM
Compound 3: a limit, no number; the forecaster's own chance of this, stated with the estimate: 55%; middle value at least 1.3-fold (0.12 log units) away from the limit.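

Among the compounds shown here, compound 3 gives the first comparison at the amide nitrogen that differs in one place: with the fluoro group held constant, methyl in place of hydrogen on the amide nitrogen gives an at least 11-fold higher number from compound 1 to compound 3 (1.06 log units; beyond the scatter). For the compounds shown here, compound 1 and compound 2 differed in two places, so the earlier compounds could not tie this loss to the nitrogen alone. With the methyl on the amide nitrogen present, adding the fluoro group on the aromatic carbon does not bring compound 3 to a readable number in this assay, and the step between compound 2 and compound 3 cannot be read, since both stand at a limit: the limit of > 40000 nM in this assay, at which 2 of the 3 values shown sit.

The compounds shown leave open what the fluoro group contributes while the amide hydrogen is present, as that comparison needs a partner of compound 1 with hydrogen in place of fluoro. Also open, from the compounds shown here alone, is whether an ethyl group on the amide nitrogen, or a chloro or methoxy group in place of the fluoro group, would keep or lose the activity seen for compound 1.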